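The source may report more compounds than this note shows. Statements on the series, on what has been measured and on what is new or still open speak of the compounds shown alone.

The three measured compounds share one core and differ only in the group on the aromatic carbon of that core. Compound 1 `CC(=O)c1c(C)nc2c(OCc3ccccc3)cccn12` carries an acetyl there and in a functional assay on the whole organism with Rattus norvegicus as the target, with a stated time of 4 h, at a dose of 40 mg/kg by the intraperitoneal route (on this read-out lower numbers stand for less inhibition and higher numbers for more inhibition at the one dose given (going by the name of the read-out)), compound 1 gives 57%. Compound 2 `Cc1nc2c(OCc3ccccc3)cccn2c1CO` carries a hydroxymethyl and in this assay compound 2 gives 99%. Compound 3 `COC(=O)Cc1c(C)nc2c(OCc3ccccc3)cccn12` carries a (methoxycarbonyl)methyl and in this assay compound 3 gives 23%, the lowest of the three numbers; its nearest neighbour is compound 1, a number 34 percentage points lower from compound 1 to compound 3 (beyond the scatter), and the furthest is compound 2, a number 76 percentage points lower from compound 2 to compound 3 (beyond the scatter).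

Compound 4 `Cc1nc2c(OCc3ccccc3)cccn2c1CC1=NCCN1` has not yet been measured. It differs from compound 3 in one place: a group of 5 heavy atoms (3 carbon, 2 nitrogen; one five-membered non-aromatic ring with 2 hetero atoms) in place of a group of 4 heavy atoms (2 carbon, 2 oxygen; no ring), on a saturated chain carbon bound to an aromatic carbon.

Within the data shown here, two measured steps bear on this change. The step of a number 76 percentage points lower from compound 2 to compound 3 (beyond the scatter) shows that, on the same saturated chain carbon, exchanging a hydroxy for a methoxycarbonyl cost a large amount of inhibition. The step of a number 34 percentage points lower from compound 1 to compound 3 (beyond the scatter) shows that the methoxycarbonyl-bearing chain also falls well short of the acetyl. The group entering in compound 4 brings back a hydrogen-bond donor, which the hydroxy of compound 2 had and the methoxycarbonyl of compound 3 lacks, so an increase is expected; it is estimated that in this assay compound 4 moves by a number 37 percentage points higher from compound 3 to compound 4 (beyond the scatter). Among the measured compounds shown here, with no direct precedent for the new ring, the estimate is broad: compound 4 is expected to give 60%, between 25% and 95%.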

Compound 4, a percentage reported as inhibition, in the whole organism at one dose (the size of the read-out at that dose, not a potency): 69%
Estimate against measurement, compound 4: 9 percentage points below; measured number inside the range.
By their numbers in this assay, from the lowest: compound 3; then compound 1; then compound 4; then compound 2.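

The result shows that the saturated chain carbon bound to an aromatic carbon can carry a ring and still keep a large part of the inhibition in this assay: the five-membered non-aromatic ring with 2 hetero atoms in place of methoxycarbonyl gives a number 46 percentage points higher from compound 3 to compound 4 (beyond the scatter) and so recovers much of what the methoxycarbonyl had given up. The ring does not fully match the hydroxy on that carbon, with a number 30 percentage points lower from compound 2 to compound 4 (beyond the scatter) in a modest step, yet the whole ring-bearing chain stands ahead of the acetyl on the aromatic carbon, with a number 12 percentage points higher from compound 1 to compound 4 (beyond the scatter) in a step that is also modest. No measurement on these groups is available to account for any of these differences.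

The compounds shown leave open whether the gain belongs to the ring itself or to the hydrogen-bond donor it carries, since no open-chain group with the same nitrogen atoms, such as an amine or an amidine, stands on that carbon. They also leave open how a carboxylic acid, a six-membered ring or a longer chain between the core and the ring would behave in this assay at this position.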